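Phenyl for methyl on an amidine, tried a second time

This account rests on a few compounds, and the source may have more. Where it says the series, first, only, none or still open, it means among the compounds named here.

Compound 1, `CC(=N)NCCC(O)c1ccccc1N`, in an assay for inhibition of Nitric oxide synthase, inducible (Homo sapiens), with a stated time of 30 min, tested at 1 mM (a higher number here means more inhibition at the concentration tested (going by the name of the read-out), a lower number less inhibition), gives 16.2%.
Compound 2, `N=C(NCCC(O)c1ccccc1N)c1ccccc1`, in this assay gives 64.1%.
Compound 3, `COc1ccc(N)c(C(=O)CCNC(C)=N)c1`, in this assay gives 97.6%.

Compound 1 and compound 2 share one core and differ in a single place: phenyl in place of methyl on a carbon with a double bond to nitrogen. That single change made a step of a number 47.9 percentage points higher from compound 1 to compound 2 (beyond the scatter), so the phenyl-bearing compound 2 inhibits far more at the test concentration than compound 1.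

Compound 3 rests on a different core. How its core differs from that of compound 1 is not broken down here. Among the three measured compounds, compound 3 gives the highest number, and its gaps to compound 2 and to compound 1 both lie beyond the usual scatter.

Compound 4, `COc1ccc(N)c(C(=O)CCNC(=N)c2ccccc2)c1`, has not yet been measured in this assay. It stands to compound 3 as compound 2 stands to compound 1: phenyl in place of methyl on a carbon with a double bond to nitrogen. The place of the change reads the same in both pairs, so it is the same change.

The first time this change was made it gave a large gain, but compound 3 leaves almost no room for a gain of that size, because compound 3 already gives 97.6%, close to the top of the scale. The expected step is therefore small, a number 0.4 percentage points higher from compound 3 to compound 4 (within the scatter). Compound 4 is estimated to give 98%, most likely between 90% and 100%.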

Compound 4, a percentage reported as inhibition, at one concentration (the size of the read-out at that concentration, not a potency): 94.7%
For compound 4 the middle estimate is 3.3 percentage points above the measured one; low and high end bracket the measured number.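

Carried to a second core, phenyl in place of methyl on a carbon with a double bond to nitrogen gave a number 2.9 percentage points lower from compound 3 to compound 4 (within the scatter), so the large gain seen on the first core did not repeat in this assay. The two steps differ, which shows that the result of this change depended on the core in these two pairs: the same change on two cores in this assay, a number 47.9 percentage points higher (beyond the scatter) from compound 1 to compound 2 and a number 2.9 percentage points lower (within the scatter) from compound 3 to compound 4, 50.8 percentage points apart, beyond the scatter of two such steps

This does not show that phenyl makes no difference on the second core, since compound 3 already gives 97.6%, close to the top of the scale, and a percentage read at a single concentration has little room there to reveal a further gain; nor do two pairs give a rule for any other core.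

The compounds shown leave open which part of the difference between the two cores goes with the different outcomes, and how the two phenyl compounds would compare with their methyl partners where the read-out is further from the top of the scale. They also leave open what an ethyl group in place of the methyl or the phenyl would do on either core, and whether a longer chain would alter the picture.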